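This account rests on a few compounds, and the source may have more. Where it says the series, first, only, none or still open, it means among the compounds named here.

Working notes on the series.

Compound 1, `O=C(CCCCC1CCSS1)Nc1ccccn1`, and compound 2, `O=C(CCCCC1CCSS1)Nc1ccc(Cl)cn1`, share one core and differ only at one aromatic carbon. In a functional assay on KB cells (Homo sapiens) for inhibition, read by MTT assay, with a stated time of 24 h, tested at 100 ug/mL (on this read-out lower numbers stand for less inhibition of growth and higher numbers for more inhibition of growth at the one concentration tested), compound 1 gives 25.1%, and compound 2 gives 74.5%. The change between them is chloro in place of hydrogen on an aromatic carbon, and it made a number 49.4 percentage points higher from compound 1 to compound 2 (beyond the scatter).

Compound 3, `O=C(CCCCC(S)CCS)Nc1ccccc1`, carries a different core; the difference between the two cores is not broken down here. In this assay compound 3 gives 15.8%, which stands within the scatter of the number for compound 1 and well apart from the number for compound 2.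

Compound 4, `O=C(CCCCC(S)CCS)Nc1ccccc1Cl`, has not yet been measured. It differs from compound 3 by chloro in place of hydrogen on an aromatic carbon. Among the measured compounds shown here, this is the same kind of change as the one from compound 1 to compound 2, not the same: there the chloro entered on a six-membered aromatic ring with 1 nitrogen, two atoms from the ring nitrogen, para to a large group, whereas here it enters on a six-membered aromatic ring of carbon only, ortho to a large group.

For the measured compounds named here, the only precedent is the step from compound 1 to compound 2, which was large. Because that step was a number 49.4 percentage points higher from compound 1 to compound 2 (beyond the scatter), an upward step is expected for compound 4 as well, but a smaller one, since the core and the place of the chloro both differ; the step expected from compound 3 to compound 4 is a number 24.2 percentage points higher from compound 3 to compound 4 (beyond the scatter). For compound 4 the estimated value in this assay is 40%, expected to fall between 15% and 70%.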

Compound 4, percent growth inhibition at one concentration: "not active" (no number reported)
No number was reported for compound 4; the estimate stays without a comparison.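

In this assay, among the compounds shown here, compound 4 is reported as "not active" with no number, so no step from compound 3 to compound 4 can be read. Nothing shown here bears on this result. The compounds shown leave open whether chloro in place of hydrogen on an aromatic carbon shifts growth inhibition on the core of compound 3 as it does on the core of compound 1.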